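Notes on compound 4 against compounds 1 to 3

The compounds below may be only part of what the source reports. "The series", "measured", "known", "first", "only" and "open" are said of these compounds alone.

Measured in a functional assay on MCF7 cells (Homo sapiens) for antiproliferative activity, read by MTT assay; on this read-out higher numbers stand for weaker inhibition and lower numbers for stronger inhibition:
compound 1 `COc1cc2c(Oc3ccc(NC(=O)Nc4cccc(C)c4)cc3)ccnc2cc1OCCCCCCC(=O)NO` gives 1240 nM;
compound 2 `COc1cc2c(Oc3ccc(NC(=O)Nc4ccc(C(F)(F)F)cc4Cl)cc3)ccnc2cc1OCCCCCCC(=O)NO` gives 500 nM;
compound 3 `COc1cc2c(Oc3ccc(NC(=O)Nc4ccccc4F)cc3)ccnc2cc1OCCCCCCC(=O)NO` gives 660 nM.

Compound 1 shows the highest of the three numbers; compound 3 sits within the scatter of it, while compound 2 lies beyond it. Compound 4 `COc1cc2c(Oc3ccc(NC(=O)NNC(=O)c4ccccc4)cc3)ccnc2cc1OCCCCCCC(=O)NO` differs from compound 1 by benzamido in place of 3-methylphenyl on an amide-type nitrogen. Within the data shown here, the steps of a 2.5-fold lower number from compound 1 to compound 2 (0.39 log units; beyond the scatter) and a 1.9-fold lower number from compound 1 to compound 3 (0.27 log units; within the scatter) change the same group on the same amide-type nitrogen, yet each puts another six-membered aromatic ring of carbon only in its place; benzamido is a group of another kind, and no measured step covers such a change. A modest step at most is therefore expected, a 1.0-fold lower number from compound 1 to compound 4 (0.01 log units; within the scatter). Compound 4 is estimated at 1200 nM, range 450 nM to 3200 nM, in this assay.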

Compound 4, half-maximal inhibitory concentration: 2450 nM
The estimate for compound 4 lay 2.0-fold (0.31 log units) below the measured number, within the range that was stated.
By their numbers in this assay, from the lowest: compounds 2, 3, 1 and 4 (each within the scatter of the next, the first and the last beyond it).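

In this assay, benzamido on this amide-type nitrogen stays within the scatter of 3-methylphenyl, a 2.0-fold higher number from compound 1 to compound 4 (0.30 log units; within the scatter), so a group of another kind, with a carbonyl and a further hydrogen-bond donor, can stand here. The halogen-bearing phenyl groups keep a gap beyond the scatter, a 3.7-fold higher number from compound 3 to compound 4 (0.57 log units; beyond the scatter) and a 4.9-fold higher number from compound 2 to compound 4 (0.69 log units; beyond the scatter). No available evidence bears on the origin of these steps.

Open, going by these compounds, is whether chloro or trifluoromethyl on the benzamido ring would bring compound 4 towards compound 2. On these data alone, a simple benzyl group or a cyclohexyl ring on this nitrogen also remains open.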